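Chloro in Place of Fluoro: Cytotoxicity in Mouse Cells

The source may report more compounds than this note shows. Statements on the series, on what has been measured and on what is new or still open speak of the compounds shown alone.

Three compounds have been measured in an ADME assay on J774 cells (Mus musculus) for cytotoxicity; a lower number here means that less compound is needed, a higher number that more compound is needed for the effect:
compound 1 `Cc1[nH]c2ccc(Cl)cc2c(=O)c1Br` gives 21700 nM;
compound 2 `Cc1[nH]c2ccc(F)cc2c(=O)c1Br` gives > 39100 nM, which is a limit of this assay and not a number;
compound 3 `CCc1c(C)[nH]c2cc(OC)c(F)cc2c1=O` gives 9400 nM.

Compound 1 and compound 2 share a core and differ in one place, (chloro in place of fluoro on an aromatic carbon), and that step is an at least 1.8-fold lower number from compound 2 to compound 1 (0.25 log units; that floor lies within the scatter). Compound 2 sits at the limit of > 39100 nM in this assay, at which 1 of the 3 values shown sits, so only a floor of that step is known. The difference between the core of compound 3 and the core of compound 2 is not broken down here. Compound 4 `CCc1c(C)[nH]c2cc(OC)c(Cl)cc2c1=O` has not yet been measured; it differs from compound 3 by chloro in place of fluoro on an aromatic carbon. This is the same kind of change as that between compound 2 and compound 1, though here the carbon is also ortho to a methoxy group. For compound 4 a step of a 1.6-fold lower number from compound 3 to compound 4 (0.19 log units; within the scatter) is expected, resting on an at least 1.8-fold lower number from compound 2 to compound 1 (0.25 log units; that floor lies within the scatter). The estimate for compound 4 is 6000 nM, between 3000 nM and 14000 nM.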

Compound 4, half-maximal effective concentration: 19000 nM
For compound 4 the middle estimate is 3.2-fold (0.50 log units) below the measured one; measured number outside the range, above it.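

On this second core, chloro in place of fluoro gives a 2.0-fold higher number from compound 3 to compound 4 (0.31 log units; beyond the scatter) in this assay. The change therefore does not carry over from one core to the other as a fixed step: the same change on two cores in this assay, an at least 1.8-fold lower number (0.25 log units; that floor lies within the scatter) from compound 2 to compound 1 and a 2.0-fold higher number (0.31 log units; beyond the scatter) from compound 3 to compound 4, at least 3.6-fold (0.56 log units) apart, beyond the scatter of two such steps. Going by these compounds, compound 2 stands at a limit of the assay and not at a number, so the earlier step is known only as a floor and its full size remains unknown: the limit of > 39100 nM in this assay, at which 1 of the 4 values shown sits.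

These four compounds leave open why the two cores differ, and whether the methoxy group ortho to the changed carbon plays any part. They also leave open how an amine or a nitrile on that same carbon would read in this assay.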